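Series notes: a further fluoro on compound 2

The source may hold more compounds than are shown below. What is called first, only, known or untested is meant among the compounds shown, and "the series" means these compounds.

Measured in a functional assay on MCF-10A cells (Homo sapiens) for antiproliferative activity, with a stated time of 48 h; a higher number here means that more compound is needed for the effect, a lower number that less compound is needed:
- compound 1 `COc1ccc2nc(C)cc(NCc3cccnc3)c2c1`: 49300 nM
- compound 2 `COc1ccc2nc(C)cc(NCc3cccc(F)c3)c2c1`: 14700 nM

Compound 2 has the lower number of the two, at 14700 nM. The next structure is compound 3 `COc1ccc2nc(C)cc(NCc3cc(F)cc(F)c3)c2c1`. The change is fluoro in place of hydrogen on an aromatic carbon, meta to a fluoro group and meta to a large group. Going by the values given here, only one measured step bears on it: a 3.4-fold lower number from compound 1 to compound 2 (0.53 log units; beyond the scatter). That modest step exchanged pyridin-3-yl for 3-fluorophenyl, a whole ring, so it is only a loose guide to adding one fluoro. In this assay, a small further fall in the number is expected, possibly none beyond the scatter. The estimated step is a 1.2-fold lower number from compound 2 to compound 3 (0.09 log units; within the scatter). For compound 3 the expected value is 12000 nM, with an estimated range of 5000 nM to 30000 nM.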

Compound 3, half-maximal effective concentration: 18100 nM
Compound 3: the middle estimate sits 1.5-fold (0.18 log units) below what was measured; the range from low to high includes it.
By their numbers in this assay, from the lowest: compounds 2 and 3 (each within the scatter of the next); then compound 1.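

Fluoro in place of hydrogen on this aromatic carbon, meta to a fluoro group, gives a 1.2-fold higher number from compound 2 to compound 3 (0.09 log units; within the scatter) in this assay, so compound 2 and compound 3 cannot be told apart at this position. Going by these compounds alone, the only earlier step, a 3.4-fold lower number from compound 1 to compound 2 (0.53 log units; beyond the scatter), exchanged a whole ring and lay beyond the scatter, whereas this single added fluoro produces no shift that can be read. No measurement on hand offers an explanation for this result.

Still open, going by these compounds, is whether a group other than fluoro on this carbon, such as methoxy, trifluoromethyl or an amine, would separate from compound 2 in this assay. Also open, on these data alone, is what a longer chain would do in place of the single saturated carbon that carries the aromatic ring.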